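Swapping an isobutyl for a methoxyphenyl on the imidazole arm

This account rests on a few compounds, and the source may have more. Where it says the series, first, only, none or still open, it means among the compounds named here.

This study tests compounds in an in vitro functional assay on cells for agonist activity at Bombesin receptor subtype-3 (Mus musculus), read by luminescence and calcium flux; a higher number here means that more compound is needed for the effect, a lower number that less compound is needed. Compound 1 `O=C(O)c1ccccc1-c1ccc(CCc2ncc(Cc3cccc(F)c3)[nH]2)cc1` gives 7.9 nM in this assay, compound 2 `O=C(O)c1ccccc1-c1ccc(CCc2ncc(CCc3ccccc3)[nH]2)cc1` gives 174 nM, and compound 3 `CC(C)CCc1cnc(CCc2ccc(-c3ccccc3C(=O)O)cc2)[nH]1` gives 10 nM. Compound 3 therefore sits close to compound 1, and the step of a 1.3-fold higher number from compound 1 to compound 3 (0.10 log units; within the scatter) is within the scatter, whereas the step of a 17-fold lower number from compound 2 to compound 3 (1.24 log units; beyond the scatter) is large.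

Compound 4 `COc1ccccc1Cc1cnc(CCc2ccc(-c3ccccc3C(=O)O)cc2)[nH]1` is the next step from compound 3: 2-methoxyphenyl in place of isobutyl on a saturated chain carbon bound to an aromatic carbon. Two measured steps speak to this. The step of a 1.3-fold higher number from compound 1 to compound 3 (0.10 log units; within the scatter) shows that a phenyl ring bearing a fluorine and an isobutyl on this chain carbon give much the same number. The step of a 22-fold higher number from compound 1 to compound 2 (1.34 log units; beyond the scatter) shows that moving a ring one carbon further out costs a great deal. Compound 4 keeps the ring directly on the chain carbon, as compound 1 does, so the number for compound 4 is expected to stay near compound 3, a step of a 1.2-fold higher number from compound 3 to compound 4 (0.08 log units; within the scatter) that lies within the scatter. The estimate for compound 4 is 12 nM, with a range from 4 nM to 40 nM.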

Compound 4, half-maximal effective concentration: 163 nM
Compound 4: the middle estimate sits 14-fold (1.13 log units) below what was measured, and the stated range ends below it.
By their numbers in this assay, from the lowest: compounds 1 and 3 (each within the scatter of the next); then compounds 4 and 2 (each within the scatter of the next).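

A ring sitting directly on this chain carbon is therefore not enough to keep the number low in this assay: 2-methoxyphenyl in place of 3-fluorophenyl gives a large loss (a 21-fold higher number from compound 1 to compound 4 (1.31 log units; beyond the scatter)), and so does 2-methoxyphenyl in place of isobutyl (a 16-fold higher number from compound 3 to compound 4 (1.21 log units; beyond the scatter)). The earlier match between a fluorinated ring and isobutyl thus does not hold for every ring-bearing group here, and 2-methoxyphenyl instead ends up level with the longer group of the weak earlier compound (a 1.1-fold lower number from compound 2 to compound 4 (0.03 log units; within the scatter)). No supporting measurement accounts for this loss.

The compounds shown leave open whether the cost follows the methoxy group or the ring itself, and plain phenyl on this chain carbon would help separate the two. They also leave open how a ring carrying an amine would behave here.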